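Triazolopyrimidine series: amine exchange at the core

This account rests on a few compounds, and the source may have more. Where it says the series, first, only, none or still open, it means among the compounds named here.

Working notes on two measured compounds and one unmeasured analogue. In an in vitro assay on 293-EBNA cells for binding affinity to corticotropin-releasing factor receptor 1 (Homo sapiens) (a lower number here means a stronger inhibitor, a higher number a weaker inhibitor), compound 1 `CCC(COC)N(C)c1nc(C)nc2c1nnn2-c1ccc(C(C)C)cc1Br` gives 11.2 nM, the lower of the two numbers available. Compound 2 `CCC(COC)Nc1nc(C)nc2c1nnn2-c1c(C)cc(C)cc1C` differs from compound 1 in both the amine and the aryl group. In this assay compound 2 gives 59.4 nM. That number lies beyond the scatter above the number of compound 1. Within the data shown here, no single-change step between measured compounds is available, so the weight of the amine alone cannot be read from the data.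

Compound 3 `CCN(CC)c1nc(C)nc2c1nnn2-c1ccc(C(C)C)cc1Br` keeps the aryl group of compound 1 and changes only the amine: a group of 5 heavy atoms (4 carbon, 1 nitrogen; no ring) in place of a group of 8 heavy atoms (6 carbon, 1 nitrogen, 1 oxygen; no ring), on an aromatic carbon. Among the measured compounds shown here, with no measured step to guide the size, a small shift toward a higher number is expected, one that may still fall within the scatter; the expected step from compound 1 to compound 3 is a 1.8-fold higher number from compound 1 to compound 3 (0.25 log units; within the scatter). For compound 3 the estimated value in this assay is 20 nM, with a range from 6 nM to 70 nM.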

Compound 3, inhibition constant: 25.3 nM
Compound 3: the middle estimate sits 1.3-fold (0.10 log units) below what was measured; measured number inside the range.
By their numbers in this assay, from the lowest: compound 1; then compound 3; then compound 2.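

With the aryl group of compound 1 held fixed, the amine on this aromatic carbon can now be weighed alone in this assay: putting diethylamino in place of the group of 8 heavy atoms gives a 2.3-fold higher number from compound 1 to compound 3 (0.35 log units; beyond the scatter), a modest step that lies beyond the scatter. The amine at this position therefore carries a measurable weight in the number, though this exchange, with no ring on either side, moves it only modestly. No measurement at hand accounts for this step. As far as these compounds go, whether the step follows the oxygen of the leaving group or the size of the chain stays open, as does the reading for cyclic amines such as morpholine or pyrrolidine, or for a longer chain such as dipropylamino. Also open, from the compounds shown here alone, is whether this amine exchange gives a similar step on the aryl group of compound 2.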